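Benzyl extension on the anilide of compound 2

A few compounds are considered here, and "the series" means these few. Any claim that something is new, unique, unknown or untested is made for them only; others in the source may bear on it.

Among the compounds with values here, in an in vitro assay on BTI-TN-5B1-4 cells for inhibition of Amine oxidase [flavin-containing] B (Homo sapiens), read by fluorescence (a higher number here means a weaker inhibitor, a lower number a stronger inhibitor), compound 1 `CC(C)CNC(=O)c1cc2ccccc2oc1=O` gives 3270 nM, and compound 2 `O=C(Nc1ccccc1)c1cc2ccccc2oc1=O` gives 760 nM, the lowest of the two numbers so far. Within the data shown here, the only measured step, a 4.3-fold lower number from compound 1 to compound 2 (0.63 log units; beyond the scatter), concerns the group on the amide nitrogen. Compound 3 `O=C(Nc1ccccc1Cc1ccccc1)c1cc2ccccc2oc1=O` carries benzyl in place of hydrogen on an aromatic carbon, placed on an aromatic carbon of a six-membered aromatic ring of carbon only, ortho to a large group. Among the measured compounds shown here, no measured step changes a substituent on that ring, so the earlier step offers no direct guide. The expected step of a 1.1-fold lower number from compound 2 to compound 3 (0.04 log units; within the scatter) is therefore none beyond the scatter, with wide uncertainty. Compound 3 is estimated at 700 nM, range 150 nM to 3500 nM.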

Compound 3, half-maximal inhibitory concentration: 910 nM
Beside the measured number, compound 3's estimate is 1.3-fold (0.11 log units) below it, and the stated range covers the measured number.
By their numbers in this assay, from the lowest: compounds 2 and 3 (each within the scatter of the next); then compound 1.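

Within the data shown here, this is the first measured substituent on the six-membered aromatic ring of carbon only: benzyl in place of hydrogen on an aromatic carbon, ortho to a large group, gives a 1.2-fold higher number from compound 2 to compound 3 (0.08 log units; within the scatter) in this assay. A whole added aromatic ring at this place therefore leaves the number indistinguishable from that of compound 2. No further evidence bears on this result.

Open, from the compounds shown here alone, is whether a smaller group such as methyl at this place would read the same. Also open, going by these compounds, is whether an amine or carboxylic acid on the added benzyl ring would shift the number.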